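Adding a Bromo Substituent to Compound 3

The compounds below may be only part of what the source reports. "The series", "measured", "known", "first", "only" and "open" are said of these compounds alone.

Compound 1 `CCCCOc1c(Br)cc(/C=C2\CCC/C(=C\c3cccc([N+](=O)[O-])c3)C2=O)cc1OC` gives 25.4 ug/mL in a functional assay on SK-N-MC cells (Homo sapiens) for cytotoxicity, read by MTT assay; a lower number here means a stronger inhibitor, a higher number a weaker inhibitor.
Compound 2 `COc1cccc(/C=C2\CCC/C(=C\c3ccc([N+](=O)[O-])cc3)C2=O)c1` gives 11.5 ug/mL.
Compound 3 `COc1cc(/C=C2\CCC/C(=C\c3ccc([N+](=O)[O-])cc3)C2=O)ccc1O` gives 48 ug/mL.

Among these three, compound 3 stands at the highest number; compound 1 lies within the scatter of it, whereas compound 2 sits further off. For the measured compounds named here, the one single-change step, a 4.2-fold higher number from compound 2 to compound 3 (0.62 log units; beyond the scatter), corresponds to hydroxy in place of hydrogen. Compound 4 `COc1cc(/C=C2\CCC/C(=C\c3ccc([N+](=O)[O-])cc3)C2=O)cc(Br)c1O` differs from compound 3 in one place: bromo in place of hydrogen on an aromatic carbon. Going by the values given here, no measured step bears directly on this change; the only step at hand concerns a hydroxy, not a bromo, and compound 1 carries its bromine on a differently substituted ring with no single-change comparison. In this assay a step no larger than the scatter is therefore expected, a 1.1-fold lower number from compound 3 to compound 4 (0.03 log units; within the scatter). Compound 4 is estimated at 45 ug/mL, between 20 ug/mL and 100 ug/mL.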

Compound 4, half-maximal inhibitory concentration: 16.8 ug/mL
The estimate for compound 4 lay 2.7-fold (0.43 log units) above the measured number, outside the stated range (below it).
By their numbers in this assay, from the lowest: compounds 2, 4, 1 and 3 (each within the scatter of the next, the first and the last beyond it).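

In this assay, bromo in place of hydrogen on the aromatic carbon ortho to a hydroxy group gives a 2.9-fold lower number from compound 3 to compound 4 (0.46 log units; beyond the scatter), so this carbon responds to substitution by a step beyond the scatter. This step runs opposite to the earlier one for hydroxy in place of hydrogen, a 4.2-fold higher number from compound 2 to compound 3 (0.62 log units; beyond the scatter). Nothing available explains the size or direction of the bromo step. The compounds shown leave open whether chloro or an amine on this same carbon would lower the number as bromo does. They also leave open whether bromo gives a similar step when the hydroxy group is absent.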